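Changing the reactive tether on the shared core

The compounds below may be only part of what the source reports. "The series", "measured", "known", "first", "only" and "open" are said of these compounds alone.

Measured compounds:
- compound 1, `O=C(CI)NCCCCCCCCNc1ncnc2c1ncn2[C@@H]1O[C@H](COP(=O)(O)OP(=O)(O)OP(=O)(O)O)[C@@H](O)[C@H]1O`: 41%
- compound 2, `CN(CCCCN(C)c1ncnc2c1ncn2[C@@H]1O[C@H](COP(=O)(O)OP(=O)(O)OP(=O)(O)O)[C@@H](O)[C@H]1O)C(=O)CCCNC(=O)CI`: 0%
- compound 3, `CN(CCCN(C)C(=O)CCCCNc1ncnc2c1ncn2[C@@H]1O[C@H](COP(=O)(O)OP(=O)(O)OP(=O)(O)O)[C@@H](O)[C@H]1O)C(=O)CCCCNC(=O)CI`: 0%

In an assay on isolated protein for inhibition of hexokinase-2 (Rattus norvegicus), with a stated time of 6 h, tested at 10 mM (on this read-out higher numbers stand for more inhibition at the one concentration tested (going by the name of the read-out) and lower numbers for less inhibition), compound 1 gives 41%, the highest of the three numbers. Compound 2 gives 0% and compound 3 gives 0%; both lie beyond the scatter below compound 1, so compound 1 stands clearly apart from the other two.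

Compound 4, `O=C(I)NCC(=O)NCCCCCCNc1ncnc2c1ncn2[C@@H]1O[C@H](COP(=O)(O)OP(=O)(O)OP(=O)(O)O)[C@@H](O)[C@H]1O`, has not yet been measured in this assay. It differs from compound 1 in one place: a group of 8 heavy atoms (3 carbon, 2 nitrogen, 2 oxygen, 1 iodine; no ring) in place of a group of 7 heavy atoms (4 carbon, 1 nitrogen, 1 oxygen, 1 iodine; no ring), on a saturated chain carbon, six bonds along the chain from a nitrogen on an aromatic ring. Among the compounds with values here, no step between two measured compounds is of this kind, so there is no direct guide to its size. The two compounds that carry a longer, amide-containing tether, compound 2 and compound 3, show no inhibition, which weighs against compound 4 keeping the full number of compound 1. A drop is therefore expected, with the step from compound 1 to compound 4 estimated at a number 21 percentage points lower from compound 1 to compound 4 (beyond the scatter). The expected value for compound 4 is 20%, within a range from 0% to 50%.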

Compound 4, a percentage reported as inhibition, at one concentration (the size of the read-out at that concentration, not a potency): 0%
The estimate for compound 4 lay 20 percentage points above the measured number; the measured number falls inside the stated range.
By their numbers in this assay, from the lowest: compounds 2, 3 and 4 (each within the scatter of the next); then compound 1.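

In this assay, the change on a saturated chain carbon, six bonds along the chain from a nitrogen on an aromatic ring, gives a number 41 percentage points lower from compound 1 to compound 4 (beyond the scatter). Within the data shown here, this is the first single-place comparison in the set, and it shows that this position is not indifferent to what it carries: a group of 8 heavy atoms cannot stand in for the 2-(((iodomethyl)carbonyl)amino)ethyl group of 7 heavy atoms without a large loss of the read-out. No measurement shown bears on why the number falls.

From the compounds shown here alone, it remains open whether a simple longer chain ending in the same iodine-bearing group would keep the inhibition of compound 1. Equally open, going by these compounds, is how a tether carrying an amine or a carboxylic acid at this place would behave.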